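Cell tolerance across the series and an estimate for compound 4

This account rests on a few compounds, and the source may have more. Where it says the series, first, only, none or still open, it means among the compounds named here.

Compound 1 `Fc1ccc(Cn2ccc3nc(-c4ccccc4)nc-3c2)cc1` gives > 100000 nM in an ADME assay on MDBK cells (Bos taurus) for cytotoxicity; a higher number here means that more compound is tolerated, a lower number that less compound is tolerated.
Compound 2 `FC(F)(F)Oc1ccc(Cn2ccc3nc(-c4ccccc4)nc-3c2)cc1` gives 66000 nM in this assay.
Compound 3 `O=C(O)c1ccc(Cn2ccc3nc(-c4ccccc4)nc-3c2)cc1` gives > 100000 nM in this assay.

Compound 1 stands at a limit of the assay, not at a number; two of the three values sit at that same limit (the limit of > 100000 nM in this assay, at which 2 of the 3 values shown sit). Among the measured steps, an at least 1.5-fold lower number from compound 1 to compound 2 (0.18 log units; that floor lies within the scatter), an at least 1.5-fold higher number from compound 2 to compound 3 (0.18 log units; that floor lies within the scatter), and a step that the two limits leave unreadable from compound 1 to compound 3.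

Compound 4 `c1ccc(-c2nc3ccn(CC4CCCCC4)cc-3n2)cc1` differs from compound 1 as follows: cyclohexyl in place of 4-fluorophenyl on a saturated chain carbon bound to an aromatic nitrogen. For the measured compounds named here, no measured step touches that place in this way; each measured step only swaps a group on the ring that compound 4 loses, so none bears directly on this change. The expectation in this assay is therefore no step beyond the scatter, an at least 1.1-fold lower number from compound 1 to compound 4 (0.04 log units; that floor lies within the scatter). Compound 4 is estimated at 90000 nM, between 40000 nM and 100000 nM.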

Compound 4, half-maximal cytotoxic concentration: > 100000 nM
Compound 4 gave a limit, no number; the forecaster's own chance of this, stated with the estimate: 55%; at least 1.1-fold (0.04 log units) between middle value and limit.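

No step can be read between compound 1 and compound 4, since each stands at a limit in this assay: the limit of > 100000 nM in this assay, at which 3 of the 4 values shown sit.

On these data alone, whether cyclohexyl in place of 4-fluorophenyl changes tolerance at all remains open.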